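Butylsulfanyl for methyl at the ring carbon of compound 2

A few compounds are considered here, and "the series" means these few. Any claim that something is new, unique, unknown or untested is made for them only; others in the source may bear on it.

Measured so far:
compound 1, `CCCCOc1nc(N)c2[nH]c(=O)n(Cc3ccccc3)c2n1`: 0.001 uM
compound 2, `Cc1nc(N)c2nc(O)n(Cc3ccccc3)c2n1`: 1 uM
compound 3, `COc1ccccc1Cn1c(O)nc2c(N)ncnc21`: 10 uM

Of the compounds shown here, three sharing a common core have been tested in a functional assay (spleen, spleen) for activation, with Mus musculus as the target; a lower number here means that less compound is needed, a higher number that more compound is needed for the effect. Compound 1 gives the lowest number, 0.001 uM. Compound 2 stands second highest of the three with 1 uM; its nearest neighbour is compound 3, whose number is higher, and the gap between them lies beyond the scatter. Compound 1 lies far below compound 2, also beyond the scatter.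

Compound 4, `CCCCSc1nc(N)c2nc(O)n(Cc3ccccc3)c2n1`, has not yet been measured. It differs from compound 2 in a single place: butylsulfanyl in place of methyl on an aromatic carbon. The methyl leaves and a butylsulfanyl chain enters on an aromatic carbon between two ring nitrogen atoms of the six-membered ring.

Going by the values given here, no measured pair shows this exact change, so the expectation rests only on the three numbers above. Compound 1 carries a four-carbon chain bound through an oxygen at the matching position and gives a far lower number than compound 2. A chain of the same length bound through sulfur is therefore expected to move the number downward by a large step, a 100-fold lower number from compound 2 to compound 4 (2.00 log units; beyond the scatter), in this assay. Compound 4 is estimated at 0.01 uM, with a range from 0.001 uM to 0.1 uM.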

Compound 4, minimum effective concentration: 0.01 uM
The estimate for compound 4 equals the measured number at the digits printed; the range from low to high includes it.
By their numbers in this assay, from the lowest: compound 1; then compound 4; then compound 2; then compound 3.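

In this assay, putting butylsulfanyl in place of methyl on the aromatic carbon between two ring nitrogen atoms gives a 100-fold lower number from compound 2 to compound 4 (2.00 log units; beyond the scatter), and this is the first change among these compounds that can be read at a single place. The earlier compounds shown here differ from one another in more than one place, so their numbers could not tie any effect to this carbon alone. This pair can, since everything else in the two molecules is the same: the group on this carbon by itself changes how much compound is needed for the effect, and by a margin well beyond the usual scatter of repeated measurements. Nothing measured here explains why the step is so large.

Still open, from the compounds shown here alone, is whether the sulfur matters or the four-carbon chain alone accounts for the step, which a plain butyl chain or a butylamino group on the same carbon would help to separate. Also open, going by these compounds, is how the number follows chain length, which shorter and longer chains such as ethylsulfanyl or hexylsulfanyl would show.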